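Methylating the hydroxy group of compound 1

The source may hold more compounds than are shown below. What is called first, only, known or untested is meant among the compounds shown, and "the series" means these compounds.

compound 1 `OCc1cn(Cc2ccc(Cl)cc2)c2ccccc12`: 79 nM
compound 2 `OCc1cn(Cc2ccc(Cl)cc2Cl)c2ccccc12`: 1580 nM

Among the measured compounds shown here, in a functional assay on T29Kt1 cells (Homo sapiens) for cytotoxicity, read by sulforhodamine B assay, with a stated time of 3 days (on this read-out higher numbers stand for weaker inhibition and lower numbers for stronger inhibition), compound 1 gives 79 nM, the lower of the two numbers measured so far. Compound 3 `COCc1cn(Cc2ccc(Cl)cc2)c2ccccc12` keeps the core of compound 1 and differs in one place: methyl in place of hydrogen on an oxygen on a saturated carbon. With methyl in place of hydrogen on an oxygen, hydroxy becomes methoxy. For the measured compounds named here, the only measured step is a 20-fold higher number from compound 1 to compound 2 (1.30 log units; beyond the scatter), made by chloro in place of hydrogen on an aromatic carbon. That is a different change, so it offers no direct guide, but it shows how far one small change moved the number here. Going by the values given here, no measured compound tests the oxygen, so a smaller rise in this assay is expected, with wide uncertainty. The estimate means a 3.8-fold higher number from compound 1 to compound 3 (0.58 log units; beyond the scatter), an expected move towards weaker inhibition. For compound 3 the expected value is 300 nM, with an estimated range of 70 nM to 1500 nM.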

Compound 3, half-maximal inhibitory concentration: 7940 nM
For compound 3 the middle estimate is 26-fold (1.42 log units) below the measured one; measured number above the stated range.
By their numbers in this assay, from the lowest: compound 1; then compound 2; then compound 3.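

In this assay the change from hydroxy to methoxy gives a 100-fold higher number from compound 1 to compound 3 (2.00 log units; beyond the scatter) and so moves the number towards much weaker inhibition. Among the compounds shown here, this is the first measured change at the oxygen of the hydroxymethyl group, and it shows that this place is far from indifferent: a methyl of just 1 heavy atom on that oxygen is enough for a large loss. No supporting measurement here explains why this single methyl has such an effect.

The two compounds cannot separate the loss of the hydrogen from the arrival of the methyl. On these data alone, it also remains open whether an amine, a carboxylic acid or a longer chain such as ethoxy in this place would behave more like the hydroxy of compound 1 or the methoxy of compound 3.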